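Expected lipophilicity after replacing an aminoamino group

The source may hold more compounds than are shown below. What is called first, only, known or untested is meant among the compounds shown, and "the series" means these compounds.

Of the compounds shown here, two have so far been measured in a physicochemical assay for lipophilicity, measured as octanol-water partition; a higher number here means a more lipophilic compound, a lower number a more polar compound. Compound 1, `CN(C)/N=N/c1ccccc1C(=O)NN`, gives 1.28 in this assay. Compound 2, `COc1ccc(C(N)=O)cc1/N=N/N(C)C`, gives 0.44. Compound 1 stands highest of the two numbers, with compound 2 the nearest and clearly lower, beyond the scatter. For the measured compounds named here, the two measured compounds do not differ in a single place, so no measured step is available to lean on.

Compound 3, `CC(=O)/N=N/C(=O)c1ccccc1/N=N/N(C)C`, has not yet been measured in this assay. It differs from compound 1 in one place: a group of 5 heavy atoms (2 carbon, 2 nitrogen, 1 oxygen; no ring) in place of a group of 2 heavy atoms (2 nitrogen; no ring), on a carbonyl carbon. The group that leaves carries two hydrogen-bond donors, and the group that enters carries none. Going by the values given here, no measured pair shows a change of this kind, so the direction rests on judgement alone. The step of a number 0.82 log units higher from compound 1 to compound 3 (beyond the scatter) is expected to be an increase beyond the scatter. Compound 3 is estimated at 2.1, within a range from 1.4 to 2.8.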

Compound 3, partition coefficient: 1.49
Estimate against measurement, compound 3: 0.61 log units above; the range from low to high includes it.
By their numbers in this assay, from the lowest: compound 2; then compounds 1 and 3 (each within the scatter of the next).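

In this assay, the step at the carbonyl carbon is a number 0.21 log units higher from compound 1 to compound 3 (within the scatter) for the exchange of the aminoamino group for a group of 5 heavy atoms. For the compounds shown here, this is the first measured one-place change at this position, and it shows that a larger group without hydrogen-bond donors can take the place of the aminoamino group with no difference that can be told from scatter. No measurement available here accounts for this result.

This single exchange changes the size of the group and its count of hydrogen-bond donors together, so their separate contributions remain unresolved. As far as these compounds go, how a carboxylic acid, a simple amine or a longer carbon chain on the same carbonyl carbon would compare with compound 1 also remains open.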